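Replacing pyrrolidin-1-yl with (sec-butoxycarbonyl)amino in a small series

The compounds below may be only part of what the source reports. "The series", "measured", "known", "first", "only" and "open" are said of these compounds alone.

Among the compounds with values here, in a functional assay on ID8 cells (Mus musculus) for antiproliferative activity (a lower number here means a stronger inhibitor, a higher number a weaker inhibitor), compound 1 (`Cc1ccc(C(=O)Nc2ccc(O)c3c(=O)cc(-c4ccccc4Cl)oc23)cc1`) gives 16000 nM and compound 2 (`O=c1cc(-c2ccccc2Cl)oc2c(N3CCCC3)ccc(O)c12`) gives 9300 nM so compound 2 stands within the scatter of the only other measured compound. Compound 3 (`CCC(C)OC(=O)Nc1ccc(O)c2c(=O)cc(-c3ccccc3Cl)oc12`) has (sec-butoxycarbonyl)amino in place of pyrrolidin-1-yl on an aromatic carbon para to a hydroxy group. Within the data shown here, no step between measured compounds sizes this change. Compound 1 also has a carbonyl-bearing group on nitrogen and gives 16000 nM so in this assay the expected step (a 1.3-fold higher number from compound 2 to compound 3 (0.11 log units; within the scatter)) stays within the scatter, with no clear direction. The estimate for compound 3 is 12000 nM (expected range from 4000 nM to 30000 nM).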

Compound 3, half-maximal inhibitory concentration: 18000 nM
Estimate against measurement, compound 3: 1.5-fold (0.18 log units) below; low and high end bracket the measured number.
By their numbers in this assay, from the lowest: compounds 2, 1 and 3 (each within the scatter of the next).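

In this assay the position para to a hydroxy group now has its first sized step: (sec-butoxycarbonyl)amino in place of pyrrolidin-1-yl gives a 1.9-fold higher number from compound 2 to compound 3 (0.29 log units; within the scatter), so this exchange does not separate the two groups. On the carbonyl carbon, sec-butoxy in place of 4-methylphenyl gives a 1.1-fold higher number from compound 1 to compound 3 (0.05 log units; within the scatter), and these two groups are not separated either. Nothing at hand bears on the reason for these results. Whether a carboxylic acid or a free amine at this position would give a number beyond the scatter of these compounds remains open.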